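The compounds below may be only part of what the source reports. "The series", "measured", "known", "first", "only" and "open" are said of these compounds alone.

Measured compounds:
compound 1 `CO[C@H]1O[C@H](CNC(=O)CN(Cc2ccccc2)C(C)=O)[C@@H](OS(=O)(=O)O)[C@H](OS(=O)(=O)O)[C@@H]1OS(=O)(=O)O` — 192000 nM
compound 2 `CCN(CC(=O)NC[C@H]1O[C@H](OC)[C@@H](OS(=O)(=O)O)[C@@H](OS(=O)(=O)O)[C@@H]1OS(=O)(=O)O)C(=O)CCCCCCCCCOS(=O)(=O)O` — 240000 nM
compound 3 `CO[C@H]1O[C@H](CNC(=O)CN(C(C)=O)c2ccccc2)[C@@H](OS(=O)(=O)O)[C@H](OS(=O)(=O)O)[C@@H]1OS(=O)(=O)O` — 480000 nM

All three were read in an assay on isolated protein for binding affinity to fibroblast growth factor 2 (Homo sapiens), read by surface plasmon resonance; on this read-out lower numbers stand for tighter binding and higher numbers for weaker binding. Compound 1 holds the lowest number of the three in this assay; compound 2 lies within the scatter of it, so no order between compound 1 and compound 2 can be drawn. Compound 3 stands furthest from compound 1, the step being a 2.5-fold higher number from compound 1 to compound 3 (0.40 log units; beyond the scatter).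

The unmeasured compound 4 `CO[C@H]1O[C@H](CNC(=O)CN(C(C)=O)C2CCCCC2)[C@@H](OS(=O)(=O)O)[C@H](OS(=O)(=O)O)[C@@H]1OS(=O)(=O)O` is reached from compound 1 by one change: cyclohexyl in place of benzyl on an amide-type nitrogen. For the measured compounds named here, the only measured step at the same place is the one from compound 1 to compound 3, where the benzyl was replaced and the number rose beyond the scatter. Going by the values given here, nothing measured tells how a non-aromatic ring at this nitrogen behaves, and compound 2, which carries a different group there, gives no step to compare. Given only that a change at this nitrogen so far weakened binding modestly, a small rise, or no step beyond the scatter, is expected.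

The estimate for compound 4 in this assay is 260000 nM, with a range of 120000 nM to 550000 nM; the expected step is a 1.4-fold higher number from compound 1 to compound 4 (0.13 log units; within the scatter).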

Compound 4, dissociation constant: 413000 nM
Beside the measured number, compound 4's estimate is 1.6-fold (0.20 log units) below it; measured number inside the range.
By their numbers in this assay, from the lowest: compounds 1, 2, 4 and 3 (each within the scatter of the next, the first and the last beyond it).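

In this assay, cyclohexyl in place of benzyl on the amide-type nitrogen gives a 2.2-fold higher number from compound 1 to compound 4 (0.33 log units; beyond the scatter), so a non-aromatic ring at this place also fails to match benzyl, as phenyl did. Cyclohexyl in place of phenyl gives a 1.2-fold lower number from compound 3 to compound 4 (0.07 log units; within the scatter), which is within the scatter, so aromatic and non-aromatic rings on this nitrogen cannot be told apart here, and among these three compounds only benzyl stands apart. No evidence on hand explains this difference.

Open, on these data alone, is whether benzyl's edge over the other two rings belongs to its aromatic ring or to the carbon that links that ring to the nitrogen; a cyclohexylmethyl group would separate the two. A 2-phenylethyl group at this nitrogen would show whether a longer link moves the number further.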